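Methyl on the Hydroxy Oxygen: Compound 2 to Compound 3

The source may report more compounds than this note shows. Statements on the series, on what has been measured and on what is new or still open speak of the compounds shown alone.

Going by the values given here, compound 2 `O=C(Nc1cccc(-n2cc(-c3ccncc3)c(-c3cc(O)cc(Cl)c3)n2)c1)Nc1ccc(Cl)c(Cl)c1` gives -5.53% in a functional assay on T47D cells (Homo sapiens) for inhibition, read by sulforhodamine B assay, with a stated time of 48 h, tested at 10 uM (a lower number here means a stronger effect, a higher number a weaker effect of the compound at the concentration tested), the lower of the two numbers measured so far; compound 1 `O=C(Nc1cccc(-n2cc(-c3ccncc3)c(-c3cc(O)cc(Cl)c3)n2)c1)Nc1ccc(Cl)c(C(F)(F)F)c1` gives 25%. Among the compounds with values here, the only measured step, a number 30.5 percentage points lower from compound 1 to compound 2 (beyond the scatter), concerns a different part of the molecule and so says nothing about the change ahead. Compound 3 `COc1cc(Cl)cc(-c2nn(-c3cccc(NC(=O)Nc4ccc(Cl)c(Cl)c4)c3)cc2-c2ccncc2)c1` differs from compound 2 by methyl in place of hydrogen on an oxygen on an aromatic ring. Within the data shown here, with no comparable step measured, no change beyond the scatter is expected, though the uncertainty is wide. Compound 3 is therefore expected to give about 5%, between -15% and 35%, an expected step of a number 10.5 percentage points higher from compound 2 to compound 3 (beyond the scatter).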

Compound 3, a percentage reported as activity, at one concentration (the size of the read-out at that concentration, not a potency): 18.6%
Estimate against measurement, compound 3: 13.6 percentage points below, and the stated range covers the measured number.
By their numbers in this assay, from the lowest: compound 2; then compounds 3 and 1 (each within the scatter of the next).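

In this assay, replacing hydroxy with methoxy gives a number 24.1 percentage points higher from compound 2 to compound 3 (beyond the scatter), so this position responds to the addition of a single methyl. Of this pair, the compound with the free hydroxy has the stronger effect at the concentration tested. Nothing available explains this difference.

From the compounds shown here alone, it remains open whether an ethyl group or a longer chain on this oxygen would shift the number further, or how an amine in place of the hydroxy would compare. Going by these compounds, the same change also remains untested against the trifluoromethyl background of compound 1.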